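Ether-to-ethylene linker change in a fluoro analogue

The source may hold more compounds than are shown below. What is called first, only, known or untested is meant among the compounds shown, and "the series" means these compounds.

Measured compounds:
compound 1, `CCN(CC)CCCC(C)/N=C(/N)NC(=O)c1cccc(Cl)c1CCc1cc(Br)ccc1OC`: 260 nM
compound 2, `CCN(CC)CCCC(C)/N=C(/N)NC(=O)c1cccc(F)c1OCc1cc(Br)ccc1OC`: 530 nM
compound 3, `COc1ccc(Br)cc1CCc1c(F)cccc1C(=O)/N=C(\N)NCCC1CCCCC1`: "not determined" (no result reported)

In a functional assay for antagonist activity at Melanocortin receptor 4 (Homo sapiens), read by cAMP accumulation (on this read-out lower numbers stand for stronger inhibition and higher numbers for weaker inhibition), compound 2 gives 530 nM, the highest of the two numbers available. Its nearest neighbour is compound 1, whose number in this assay is lower by more than the usual scatter. Compound 3 carries a different amine side chain, and in this assay compound 3 gives "not determined" (no result reported), so no number is available for it.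

Compound 4, `CCN(CC)CCCC(C)/N=C(/N)NC(=O)c1cccc(F)c1CCc1cc(Br)ccc1OC`, differs from compound 2 in one place: a group of 11 heavy atoms (9 carbon, 1 oxygen, 1 bromine; one six-membered aromatic ring of carbon only) in place of a group of 11 heavy atoms (8 carbon, 2 oxygen, 1 bromine; one six-membered aromatic ring of carbon only), on an aromatic carbon. Going by the values given here, the entering group is the one that compound 1 also carries, and compound 1 gives 260 nM in this assay. On that basis the step from compound 2 to compound 4 is expected to run towards a lower number, of modest size, possibly not beyond the scatter, estimated as a 1.8-fold lower number from compound 2 to compound 4 (0.25 log units; within the scatter). Compound 4 is accordingly expected to give about 300 nM in this assay, with a plausible range from 120 nM to 800 nM.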

Compound 4, half-maximal inhibitory concentration: 130 nM
For compound 4 the middle estimate is 2.3-fold (0.36 log units) above the measured one; the range from low to high includes it.
By their numbers in this assay, from the lowest: compounds 4 and 1 (each within the scatter of the next); then compound 2.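

In this assay, the 2-(5-bromo-2-methoxyphenyl)ethyl group in place of the ether-linked group, on the aromatic carbon ortho to a fluoro group, gives a 4.1-fold lower number from compound 2 to compound 4 (0.61 log units; beyond the scatter). Going by these compounds alone, this is the first change at this position with the rest of the molecule held constant, and it shows that the linking atoms alone shift the number by more than the scatter. Fluoro in place of chloro, with the 2-(5-bromo-2-methoxyphenyl)ethyl group kept, gives a 2.0-fold lower number from compound 1 to compound 4 (0.30 log units; within the scatter), so the two halogens cannot be told apart here, and no measurement offered accounts for the linker step.

From the compounds shown here alone, it remains open whether the same linker change holds with chloro in place of fluoro, and how an amine or a longer chain linking the two rings would read. The cyclohexylethyl side chain of compound 3 also stays unplaced, as it has no number to compare.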